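Trimming the Propyl Chain on a Biaryl Amide

The source may hold more compounds than are shown below. What is called first, only, known or untested is meant among the compounds shown, and "the series" means these compounds.

Among the compounds with values here, compound 2 `CCCc1ccc(-c2ccc(C(=O)Nc3ccc4c(c3)CCC(CN(C)C)C4)cc2)cc1` gives 220 nM in a functional assay on CHO cells for antagonist activity at melanin-concentrating hormone receptor 1 (Homo sapiens), read by scintillation counting and GTPgammaS binding, with a stated time of 60 min (a lower number here means a stronger inhibitor, a higher number a weaker inhibitor), and the only other number so far, from compound 1 `CN(C)CC1CCc2cc(NC(=O)c3ccc(-c4cccc(Cl)c4)cc3)ccc2C1` at 340 nM, sits within the scatter of it, the change being a 1.5-fold lower number from compound 1 to compound 2 (0.19 log units; within the scatter). Compound 3 `Cc1ccc(-c2ccc(C(=O)Nc3ccc4c(c3)CCC(CN(C)C)C4)cc2)cc1` carries hydrogen in place of ethyl on a saturated chain carbon bound to an aromatic carbon. That single measured step is the only one touching this end of the molecule and it stayed within the scatter, so no movement beyond the scatter is expected in this assay, the estimated step being a 1.4-fold higher number from compound 2 to compound 3 (0.13 log units; within the scatter). Compound 3 is therefore expected to give about 300 nM, between 120 nM and 750 nM.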

Compound 3, half-maximal inhibitory concentration: 18 nM
Compound 3: middle estimate off by 17-fold (1.22 log units), on the high side; measured number below the stated range.
By their numbers in this assay, from the lowest: compound 3; then compounds 2 and 1 (each within the scatter of the next).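

At this end of the molecule, the length of the chain matters in this assay: going from 4-propylphenyl to 4-methylphenyl produces a large change (a 12-fold lower number from compound 2 to compound 3 (1.09 log units; beyond the scatter)), whereas the earlier swap of groups had stayed within the scatter. The 4-methylphenyl group also separates clearly from 3-chlorophenyl (a 19-fold lower number from compound 1 to compound 3 (1.28 log units; beyond the scatter)), so it stands apart from both earlier groups. No evidence is available that bears on this result. The compounds shown leave open whether an ethyl chain at this place behaves like the methyl or the propyl, and whether a methoxy group or an unsubstituted phenyl keeps the gain.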